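A few compounds are considered here, and "the series" means these few. Any claim that something is new, unique, unknown or untested is made for them only; others in the source may bear on it.

Measured so far in an ADME assay on WI-38 cells (Homo sapiens) for inhibition, read by CellTiter-Glo, with a stated time of 4 days; on this read-out higher numbers stand for weaker inhibition of growth and lower numbers for stronger inhibition of growth:
- compound 1 `Oc1cc(-c2ccccc2)nn1-c1ccccc1`: > 30000 nM
- compound 2 `Oc1cc(-c2ccccc2)nn1-c1ccc(F)cn1`: 28900 nM

Going by the values given here, compound 2 carries the only actual number here. Compound 1 gives a limit of the assay, not a number: the limit of > 30000 nM in this assay, at which 1 of the 2 values shown sits. Compound 3 `COc1ccc(-n2nc(-c3ccccc3)cc2O)nc1` differs from compound 2 by methoxy in place of fluoro on an aromatic carbon. Among the compounds with values here, no measured pair isolates this change, so nothing shows its direction. With compound 2 already near the limit, a step no larger than the usual scatter is expected either way. Compound 3 is therefore estimated at 30000 nM, between 12000 nM and 80000 nM, a step of a 1.0-fold higher number from compound 2 to compound 3 (0.02 log units; within the scatter), with a real chance that only a limit is reported.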

Compound 3, concentration for 50% growth inhibition: 25400 nM
Beside the measured number, compound 3's estimate is 1.2-fold (0.07 log units) above it; low and high end bracket the measured number.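

In this assay, methoxy in place of fluoro on an aromatic carbon, para to a large group, gives a 1.1-fold lower number from compound 2 to compound 3 (0.06 log units; within the scatter). This first measured pair therefore shows that the two groups cannot be told apart at this position, even though methoxy has one more heavy atom and a hydrogen-bond acceptor. Compound 1 gives a limit, not a number: the limit of > 30000 nM in this assay, at which 1 of the 3 values shown sits.

As far as these compounds go, whether an amine or a carboxylic acid at this position would give a clearly different value remains open. So does the effect of changes elsewhere on the shared core.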